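The source may report more compounds than this note shows. Statements on the series, on what has been measured and on what is new or still open speak of the compounds shown alone.

Values in a functional assay on ECa-109 cells (Homo sapiens) for antiproliferative activity, read by MTT assay, with a stated time of 72 h; a higher number here means a weaker inhibitor, a lower number a stronger inhibitor:

- Compound 1 `CCCSc1nc(N/N=C/c2cccnc2)c2nnn(Cc3ccccc3)c2n1`: > 64000 nM (a limit of the assay, not a number)
- Compound 2 `CCCSc1nc(N/N=C(\C)c2ccc(O)cc2)c2nnn(Cc3ccccc3)c2n1`: 32500 nM
- Compound 3 `CCCSc1nc(N/N=C/c2ccccc2Cl)c2nnn(Cc3ccccc3)c2n1`: 6180 nM

Compound 3 has the lowest number of the three, which makes it the strongest inhibitor shown. Compound 4 `CCCSc1nc(N/N=C/c2ccc(Cl)cc2)c2nnn(Cc3ccccc3)c2n1` has the same atoms, joined differently: 4-chlorophenyl in place of 2-chlorophenyl on a carbon with a double bond to nitrogen. In words, it carries 4-chlorophenyl in place of 2-chlorophenyl on a carbon with a double bond to nitrogen.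

Two measured steps end at compound 3 and change the group at this carbon: an at least 10-fold lower number from compound 1 to compound 3 (1.01 log units; beyond the scatter) and a 5.3-fold lower number from compound 2 to compound 3 (0.72 log units; beyond the scatter). Both show that changes here can move the number well beyond the scatter. Neither step moves the chlorine, however, so they give no direction for this change. The value of compound 3 remains the best starting point, with a wide margin on either side.

No shift beyond the scatter is expected, and the estimated step is a 1.3-fold higher number from compound 3 to compound 4 (0.11 log units; within the scatter). For compound 4 the expected value is 8000 nM, with an estimated range of 2500 nM to 26000 nM.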

Compound 4, half-maximal inhibitory concentration: > 64000 nM
Compound 4: no number, only a limit (the forecaster's own chance of this, stated with the estimate: 8%); middle value at least 8.0-fold (0.90 log units) from the limit.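

The earlier steps shown here at this carbon exchanged the whole group, whereas this one only moves the chlorine, and that move alone gives an at least 10-fold higher number from compound 3 to compound 4 (1.01 log units; beyond the scatter). In this assay compound 4 gives > 64000 nM, which is a limit of the assay and not a number. The comparison with compound 2 adds little, as it shows an at least 1.9-fold higher number from compound 2 to compound 4 (0.29 log units; that floor lies within the scatter), and the step between compound 1 and compound 4 cannot be read, since both share the same limit: the limit of > 64000 nM in this assay, at which 2 of the 4 values shown sit.

From the compounds shown here alone, how far compound 4 really lies past that limit remains open, so the full size of the move is unknown. Also open, going by these compounds, is whether an amine or a methoxy group in place of the chlorine would give a number closer to that of compound 3 or to that of compound 4.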